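A carboxy group at the limit of the assay

A few compounds are considered here, and "the series" means these few. Any claim that something is new, unique, unknown or untested is made for them only; others in the source may bear on it.

Compound 1 (`Cc1cc(NC(=O)Nc2ccc(N(C)C)cc2)c2ccccc2n1`) and compound 2 (`Cc1cc(NC(=O)Nc2ccc(C(N)=O)cc2)c2ccccc2n1`) share one core and differ in a single group. In an ADME assay on Raji cells (Homo sapiens) for cytotoxicity, with a stated time of 72 h (on this read-out lower numbers stand for an effect already at smaller amounts and higher numbers for an effect only at larger amounts of compound), compound 1 gives > 25000 nM as a limit of the assay and not as a number. Compound 2 gives > 25000 nM as a limit too, so it has no exact place on the scale. The record so far is simply the limit of > 25000 nM in this assay, at which 2 of the 2 values shown sit, and nothing finer.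

Compound 3 (`Cc1cc(NC(=O)Nc2ccc(C(=O)O)cc2)c2ccccc2n1`) carries one change from compound 2: hydroxy in place of amino on a carbonyl carbon, which can also be read as carbamoyl to carboxy. Going by the values given here, one measured step bears on this (a step that the two limits leave unreadable from compound 1 to compound 2). It brought in the carbamoyl group now being replaced, and it offers no size to carry over. The expectation of no step beyond the scatter in this assay, in either direction, rests on compound 2 and its limit of > 25000 nM alone. As a number, the expected change is a step that the limit leaves unreadable from compound 2 to compound 3 and no more than an estimate. The estimate for compound 3 is 30000 nM with an expected range from 15000 nM to 60000 nM and a good chance that the outcome is only a limit of the assay.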

Compound 3, half-maximal effective concentration: > 25000 nM
Compound 3 was reported as a limit; the forecaster's own chance of this, stated with the estimate: 85%; the middle value lies beyond the limit too.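

No step among compound 1, compound 2 and compound 3 can be read in this assay, since each gives only a limit of the assay and not a number: the limit of > 25000 nM in this assay, at which 3 of the 3 values shown sit.

What these compounds leave open is where each one truly stands on the scale, and whether changing this one group on the shared core alters the read-out at all.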